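Returning to a short chain on the shared core

The source may hold more compounds than are shown below. What is called first, only, known or untested is meant among the compounds shown, and "the series" means these compounds.

Compound 3, `COc1ccc(F)cc1-c1cccc(-c2nn(CCOC3CCCCO3)c(=O)o2)c1`, gives 44% in a functional assay on the whole organism (strain Wistar albino) for inhibition, with Rattus norvegicus as the target, read by paw edema, with stated times of 30 min and 1.5 h, at a dose of 10 mg/kg by the oral route (on this read-out lower numbers stand for less inhibition and higher numbers for more inhibition at the one dose given (going by the name of the read-out)), and is the lowest of the three numbers measured. Its neighbours are compound 1, `COc1ccc(F)cc1-c1cccc(-c2nn(CCCC#N)c(=O)o2)c1`, which gives 59% in this assay, and compound 2, `COc1ccc(F)cc1-c1cccc(-c2nn(CCCCF)c(=O)o2)c1`, which gives 67%. The steps to compound 3 both point downward: a number 15 percentage points lower from compound 1 to compound 3 (beyond the scatter) and a number 23 percentage points lower from compound 2 to compound 3 (beyond the scatter), while the step between the other two, a number 8 percentage points higher from compound 1 to compound 2 (within the scatter), stays inside the scatter.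

Compound 4, `COc1ccc(F)cc1-c1cccc(-c2nn(CCCN)c(=O)o2)c1`, differs from compound 3 in one place: aminomethyl in place of (oxan-2-yl)oxy on a saturated chain carbon, two bonds along the chain from an aromatic nitrogen. For the measured compounds named here, both of the measured steps that touch this position were reductions on arriving at the (oxan-2-yl)oxy group, so the only evidence available points to a gain in this assay when that group is replaced by a small aminomethyl, though no step with an aminomethyl has been measured. Compound 4 is therefore expected to give 58%, with a range from 45% to 72%. This expectation amounts to a step of a number 14 percentage points higher from compound 3 to compound 4 (beyond the scatter), an estimated rise that would bring compound 4 back near compounds 1 and 2.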

Compound 4, a percentage reported as inhibition, in the whole organism at one dose (the size of the read-out at that dose, not a potency): 55%
Compound 4: the middle estimate sits 3 percentage points above what was measured, and the stated range covers the measured number.
By their numbers in this assay, from the lowest: compound 3; then compounds 4, 1 and 2 (each within the scatter of the next, the first and the last beyond it).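

Replacing (oxan-2-yl)oxy with aminomethyl gives a number 11 percentage points higher from compound 3 to compound 4 (beyond the scatter) in this assay, so the low number of compound 3 does not carry over to a chain ending in an amine. Amino in place of cyano gives a number 4 percentage points lower from compound 1 to compound 4 (within the scatter) and leaves compound 4 and compound 1 indistinguishable in this read-out. Amino in place of fluoromethyl gives a number 12 percentage points lower from compound 2 to compound 4 (beyond the scatter) and places compound 4 under compound 2, the first sign that the group at the chain end can separate two short chains at this position. Nothing at hand explains these differences.

Still open, going by these compounds, is how a methylated amine, a carboxylic acid or a longer chain ending in an amine would read at this position. With a single dose, the compounds shown also leave open how these numbers would hold at other doses.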